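Compound 1 loses its 2-methoxyethoxy group

The compounds below may be only part of what the source reports. "The series", "measured", "known", "first", "only" and "open" are said of these compounds alone.

Compound 1 `CC#C[C@@H](Cc1nnn[nH]1)c1ccc(OCc2ccc3scc(-c4cc(OCCOC)ccc4C)c3c2)cc1` – 0.367 h
Compound 2 `CC#C[C@@H](Cc1nnn[nH]1)c1ccc(OCc2ccc3sc(C)c(-c4ccc(OCCOC)cc4C)c3c2)cc1` – 0.117 h
Compound 3 `CC#C[C@@H](Cc1nnn[nH]1)c1ccc(OCc2ccc3sc(C)c(-c4ccccc4C)c3c2)cc1` – 0.483 h

All three values come from an ADME assay on microsomes from liver (Rattus norvegicus) for metabolic stability (on this read-out higher numbers stand for a longer-lived compound and lower numbers for a shorter-lived compound), and compound 1 lies within the scatter of compound 3 and clearly above compound 2. Compound 4 `CC#C[C@@H](Cc1nnn[nH]1)c1ccc(OCc2ccc3scc(-c4ccccc4C(F)(F)F)c3c2)cc1` has not yet been measured. Its difference from compound 1 is 2-(trifluoromethyl)phenyl in place of 5-(2-methoxyethoxy)-2-methylphenyl on an aromatic carbon on an aromatic carbon of a five-membered aromatic ring with 1 sulfur, two ring bonds from the ring sulfur.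

Among the measured compounds shown here, the one measured step that bears on this is a 4.1-fold higher number from compound 2 to compound 3 (0.62 log units; beyond the scatter) and it also takes away a 2-methoxyethoxy group. It is only a partial guide. For the measured compounds named here, no measured step shows the effect of bringing in 2-(trifluoromethyl)phenyl, and compounds 2 and 3 have a core that differs from the core of compound 1. Compound 3 at 0.483 h lacks the 2-methoxyethoxy group yet stands within the scatter of compound 1, which argues against carrying over the whole step. A rise smaller than the measured one is therefore expected, and the estimate is a 2.2-fold higher number from compound 1 to compound 4 (0.34 log units; beyond the scatter) in this assay. Compound 4 is estimated at 0.8 h with an expected range of 0.35 h to 1.8 h for its half-life.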

Compound 4, half-life: 0.167 h
Compound 4: the middle estimate sits 4.8-fold (0.68 log units) above what was measured, outside the stated range (below it).
By their numbers in this assay, from the lowest: compounds 2 and 4 (each within the scatter of the next); then compounds 1 and 3 (each within the scatter of the next).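

On the aromatic carbon two ring bonds from the ring sulfur of the core of compound 1, in this assay, replacing 5-(2-methoxyethoxy)-2-methylphenyl with 2-(trifluoromethyl)phenyl gives a 2.2-fold lower number from compound 1 to compound 4 (0.34 log units; beyond the scatter) and so does not lengthen the half-life. The step that removes the 2-methoxyethoxy group from the other core points the opposite way, a 4.1-fold higher number from compound 2 to compound 3 (0.62 log units; beyond the scatter), so among these compounds, losing that group does not go with a higher number on both cores, with compound 4 standing against the pattern set by compound 3. Nothing shown gives a measured property that would account for this fall in compound 4.

The compounds shown leave open whether the fall follows the loss of the 2-methoxyethoxy group, the loss of the methyl group or the arrival of the trifluoromethyl group, as all of these changes come together in this one step. Also open, going by these compounds, is how a phenyl ring carrying a chlorine, a nitrile or a morpholine would stand at this place on the core of compound 1.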